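A few compounds are considered here, and "the series" means these few. Any claim that something is new, unique, unknown or untested is made for them only; others in the source may bear on it.

Working notes on the series.

For the measured compounds named here, compound 3 `N#Cc1cccc(S(=O)(=O)N2CCC(NS(=O)(=O)c3cc(S(=O)(=O)c4ccccc4)ccc3C(F)(F)F)CC2)c1` gives 90 nM in an assay on isolated protein for displacement of a labelled ligand from secreted frizzled-related protein 1 (Homo sapiens), read by fluorescence polarization, with a stated time of 30 min (on this read-out higher numbers stand for weaker inhibition and lower numbers for stronger inhibition), the second highest of the three numbers so far; its nearest neighbour is compound 2 `O=C(c1cccnc1)N1CCC(NS(=O)(=O)c2cc(S(=O)(=O)c3ccccc3)ccc2C(F)(F)F)CC1`, which gives 80 nM, and the step of a 1.1-fold higher number from compound 2 to compound 3 (0.05 log units; within the scatter) lies within the scatter. Compound 1 `O=C(c1ccc(C(F)(F)F)cc1)N1CCC(NS(=O)(=O)c2cc(S(=O)(=O)c3ccccc3)ccc2C(F)(F)F)CC1` gives 400 nM, and the steps of a 5.0-fold lower number from compound 1 to compound 2 (0.70 log units; beyond the scatter) and a 4.4-fold lower number from compound 1 to compound 3 (0.65 log units; beyond the scatter) are both beyond the scatter.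

Compound 4 `O=C([C@@H]1CCNC1)N1CCC(NS(=O)(=O)c2cc(S(=O)(=O)c3ccccc3)ccc2C(F)(F)F)CC1` carries the change ((pyrrolidin-3-yl)carbonyl in place of (3-cyanophenyl)sulfonyl on an amine nitrogen in a ring). Going by the values given here, the measured steps bear on it only loosely: the two steps to compound 3 and to compound 2 show that exchanging one group at this amine nitrogen can shift the number by a modest amount in either direction, while no measured pair exchanges an aromatic group for a non-aromatic ring at this position. The expected step is therefore small, with a wide range, and is put at a 2.2-fold higher number from compound 3 to compound 4 (0.35 log units; beyond the scatter) toward a higher number.

Compound 4 is estimated at 200 nM, expected to lie between 50 nM and 800 nM.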

Compound 4, half-maximal inhibitory concentration: 60 nM
Compound 4: the middle estimate sits 3.3-fold (0.52 log units) above what was measured; the measured number falls inside the stated range.
By their numbers in this assay, from the lowest: compounds 4, 2 and 3 (each within the scatter of the next); then compound 1.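

In this assay, the amine nitrogen in the ring tolerates a non-aromatic group: the steps of a 1.5-fold lower number from compound 3 to compound 4 (0.18 log units; within the scatter) and a 1.3-fold lower number from compound 2 to compound 4 (0.12 log units; within the scatter) show that neither an aromatic ring nor a sulfonyl link is required in this series to keep the number in this range. Among the carbonyl compounds, 4-(trifluoromethyl)phenyl stands apart, with a 6.7-fold lower number from compound 1 to compound 4 (0.82 log units; beyond the scatter), so pyrrolidin-3-yl and pyridin-3-yl read alike here while that substituted phenyl does not. Nothing measured explains this difference.

Going by these compounds, it remains open how the other stereoisomer of the pyrrolidin-3-yl group would read. Also open, on these data alone, is whether a methyl group on the pyrrolidine nitrogen, or an open-chain amine on the carbonyl carbon, would hold the number at this position.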